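Configuration Alone: Three Stereoisomers in a Cell Assay

The source may report more compounds than this note shows. Statements on the series, on what has been measured and on what is new or still open speak of the compounds shown alone.

Measured so far:
compound 1, `O=C(c1ccc(O)cc1O)[C@@H]1[C@H](C(=O)c2ccc(O)cc2O)[C@@H](c2ccccc2)[C@H]1c1ccccc1`: 78.8%
compound 2, `O=C(c1ccc(O)cc1O)[C@H]1[C@H](C(=O)c2ccc(O)cc2O)[C@H](c2ccccc2)[C@@H]1c1ccccc1`: 87.6%

Compound 1 and compound 2 share every atom and bond and differ only in how one stereocentre is drawn. In a functional assay on PC-3 cells (Homo sapiens) for cytotoxicity, read by MTT assay, with a stated time of 48 h, tested at 25 uM (a lower number here means a weaker effect, a higher number a stronger effect of the compound at the concentration tested), compound 1 gives 78.8%, and compound 2 gives 87.6%. The step of a number 8.8 percentage points higher from compound 1 to compound 2 (within the scatter) is within the scatter, so the two numbers cannot be told apart. On the numbers shown, compound 2 carries the higher figure, with compound 1 the nearest, and the gap between them is within the scatter. Going by the values given here, the only evidence on this step is that the pair differs solely in configuration as drawn (the fact that compounds 1 and 2 differ only in the configuration as drawn).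

Compound 3, `O=C(c1ccc(O)cc1O)[C@@H]1[C@@H](C(=O)c2ccc(O)cc2O)[C@H](c2ccccc2)[C@H]1c1ccccc1`, has not yet been measured. Relative to compound 2 the change is the two compounds have the same atoms and bonds and differ only in configuration as drawn: 3 of 4 stereo elements differ; a stereocentre at a saturated ring carbon is drawn R in compound 2 and S in compound 3; a stereocentre at a saturated ring carbon is drawn R in compound 2 and S in compound 3; a stereocentre at a saturated ring carbon is drawn S in compound 2 and R in compound 3. Among the compounds with values here, the single measured step that bears on it, a number 8.8 percentage points higher from compound 1 to compound 2 (within the scatter), changed one stereo element and stayed within the scatter. Here three stereo elements change at once, and no measured pair shows how such a larger redrawing plays out, so the uncertainty is wider. Compound 3 is nevertheless expected to land near the two measured numbers, with a number 7.6 percentage points lower from compound 2 to compound 3 (within the scatter) estimated as no step beyond the scatter. The estimate for compound 3 is 80%, within 55% to 95%.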

Compound 3, a percentage reported as activity, at one concentration (the size of the read-out at that concentration, not a potency): 96.3%
Beside the measured number, compound 3's estimate is 16.3 percentage points below it; measured number above the stated range.
By their numbers in this assay, from the lowest: compounds 1, 2 and 3 (each within the scatter of the next, the first and the last beyond it).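

In this assay, this result supplies the first step among these stereoisomers that clears the scatter: a number 17.5 percentage points higher from compound 1 to compound 3 (beyond the scatter). That step redraws two stereocentres at saturated ring carbons, while a number 8.7 percentage points higher from compound 2 to compound 3 (within the scatter) redraws three and stays within the scatter, so the number of redrawn stereocentres alone does not track the size of the step in these pairs. The pair with the step beyond the scatter shares every atom and bond, which shows that configuration alone can be enough to give a modest shift in this read-out: the fact that compounds 1 and 3 differ only in the configuration as drawn.

Going by these compounds, the three compounds carry the same groups throughout, so it remains open whether an amine or a carboxylic acid in place of a hydroxyl group would move the number at all. On these data alone, each figure also comes from a single concentration and gives the size of the effect there rather than a potency, so it remains open whether the separation between these stereoisomers would hold at other concentrations.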